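This account rests on a few compounds, and the source may have more. Where it says the series, first, only, none or still open, it means among the compounds named here.

Working notes on the series built around the core of compound 1 `Cn1nc(N)c(/N=N/c2ccncc2)c1N`. In a functional assay on RPMI-8226 cells (Homo sapiens) for cytotoxicity, read by fluorescence, with a stated time of 72 h (a lower number here means a stronger inhibitor, a higher number a weaker inhibitor), compound 1 gives 50000 nM. Compound 2 `CC(=O)n1nc(N)c(/N=N/c2ccc(O)cc2)c1N` belongs to the same set. In this assay compound 2 reaches only a limit, > 100000 nM, and no number. Compound 1 thus stands as the only entry in this assay that is read as a number. Compound 2 sits at the limit of > 100000 nM in this assay, at which 1 of the 2 values shown sits. Compound 3 `Nc1n[nH]c(N)c1/N=N/c1ccncc1` has not yet been measured in this assay. It differs from compound 1 in one place: hydrogen in place of methyl on an aromatic nitrogen. Going by the values given here, no step between two measured compounds that differ in a single place is available, so the size of this change cannot be taken from a measured pair. The change is small in atoms, a methyl replaced by hydrogen on an aromatic nitrogen, and the step expected in this assay, a 1.2-fold higher number from compound 1 to compound 3 (0.08 log units; within the scatter), is not expected to exceed the usual scatter in either direction. Compound 3 is therefore expected to give about 60000 nM in this assay, with a range from 20000 nM to 150000 nM.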

Compound 3, half-maximal inhibitory concentration: 6200 nM
Compound 3: the middle estimate sits 9.7-fold (0.99 log units) above what was measured; measured number below the stated range.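

In this assay, the aromatic nitrogen of the five-membered ring proves sensitive to its substituent: hydrogen in place of methyl gives an 8.1-fold lower number from compound 1 to compound 3 (0.91 log units; beyond the scatter), the first single-place step read in this series. The change removes only a single carbon, so even the smallest edit at this position can move the number beyond the scatter, at least on this one pair and in the direction of a stronger inhibitor. Going by these compounds alone, nothing measured so far accounts for the size or direction of this step.

The compounds shown leave open whether the number follows the size of the group on this nitrogen, which an ethyl group, a longer alkyl chain or a chain ending in an amine would test against the hydrogen of compound 3 and the methyl of compound 1. Compound 2 differs from compound 1 and compound 3 in more than one place, so it offers no second comparison for this position, and whether the step carries over to other groups on the shared core remains unsettled.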